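Changing one ring on the lowest of three compounds

This account rests on a few compounds, and the source may have more. Where it says the series, first, only, none or still open, it means among the compounds named here.

So far three compounds have been measured in a physicochemical assay for lipophilicity; on this read-out higher numbers stand for higher lipophilicity and lower numbers for lower lipophilicity. Compound 1 `c1ccc(COCCCCN2CCCCC2)cc1` gives 5.8, compound 2 `COc1ccccc1OCCCC1CCOCC1` gives 3.4, and compound 3 `COc1ccccc1OCCOC1CCOCC1` gives 2.1. Compound 3 is therefore the lowest of the three. Compound 2 is its nearest neighbour and compound 1 lies furthest away, and both gaps are beyond the usual scatter of such measurements.

The next compound, compound 4 `COc1ccccc1OCCON1CCOCC1`, has morpholin-4-yl in place of oxan-4-yl on an oxygen on a saturated carbon. Going by the values given here, no pair of measured compounds shows this exchange, so the size of the step cannot be read directly from the data. With compound 3 at 2.1 as the starting point, the expectation rests only on the hetero atoms and acceptors counted in that change. A moderate fall in this assay is expected, an estimated a number 0.70 log units lower from compound 3 to compound 4 (beyond the scatter). For compound 4 the estimated value is 1.4, with an expected range from 0.8 to 2.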

Compound 4, partition coefficient: 2.1
Beside the measured number, compound 4's estimate is 0.70 log units below it; the whole stated range lies below it.
By their numbers in this assay, from the lowest: compounds 3 and 4 (each within the scatter of the next); then compound 2; then compound 1.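

Within this assay the exchange of oxan-4-yl for morpholin-4-yl on an oxygen on a saturated carbon shows no change at the digits printed from compound 3 to compound 4 (within the scatter) and gives the first direct reading of a change at this position. The entering ring has 2 hetero atoms and 2 hydrogen-bond acceptors where the leaving ring has 1 of each, so for this pair those added counts come with no shift larger than the scatter. No measurement at hand explains this result.

One pair cannot show whether other groups on this oxygen, such as a piperidine ring, an open-chain amine or a carboxylic acid, would also leave the number in place. On these data alone, it also remains open whether morpholin-4-yl in place of oxan-4-yl would give the same reading in the core of compound 2.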